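Dog liver microsome stability: from compound 2 to compound 3

This account rests on a few compounds, and the source may have more. Where it says the series, first, only, none or still open, it means among the compounds named here.

Compound 1 `C=CC(=O)NCc1coc(-c2c(N)ncnc2Nc2ccc(Oc3ccccc3)c(Cl)c2)n1` and compound 2 `C=CC(=O)NCc1coc(-c2c(N)ncnc2Nc2ccc(Oc3cc(Cl)ccc3Cl)c(Cl)c2)n1` share one core and differ only in the group carried on the oxygen on the aromatic ring. In an in vitro ADME assay on microsomes from liver (Canis lupus familiaris) for metabolic stability, tested at 5 uM (a higher number here means that the compound lasts longer, a lower number that the compound disappears faster), compound 1 gives > 1.66 h, which is a limit of the assay and not a number. In this assay compound 2 gives > 1.66 h, again a limit rather than a number. The step that the two limits leave unreadable from compound 1 to compound 2 is therefore unreadable in size, and compound 2 stands at the limit, as summarised by the limit of > 1.66 h in this assay, at which 2 of the 2 values shown sit, with no number of its own.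

Compound 3 `C=CC(=O)NCc1coc(-c2c(N)ncnc2Nc2ccc(Oc3cccc(F)c3)c(Cl)c2)n1` differs from compound 2 by 3-fluorophenyl in place of 2,5-dichlorophenyl on an oxygen on an aromatic ring. Going by the values given here, the only measured step that bears on this position is a step that the two limits leave unreadable from compound 1 to compound 2, and its size is hidden by the two limits, so no step beyond the scatter can be read from it in either direction. Compound 3 is therefore expected to remain near the limit, with a step that the limit leaves unreadable from compound 2 to compound 3 as the expected step. For compound 3 the expected half-life in this assay is 2 h, with a range from 1 h to 4.5 h.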

Compound 3, half-life: > 1.66 h
Compound 3: only a limit was reported; the forecaster's own chance of this, stated with the estimate: 70%; the middle value does not contradict the limit.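

In this assay no new step can be read among compound 1, compound 2 and compound 3, since all three stand at a limit of the assay and not at a number: the limit of > 1.66 h in this assay, at which 3 of the 3 values shown sit.

Left open is the actual half-life of each compound, and whether phenyl, 2,5-dichlorophenyl or 3-fluorophenyl on the oxygen changes it at all.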